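Series notes: aromatic methyl removal in the piperazinyl tetrahydroisoquinoline set

The source may report more compounds than this note shows. Statements on the series, on what has been measured and on what is new or still open speak of the compounds shown alone.

Measured so far:
compound 1 `CCN(C[C@H]1Cc2c(cccc2N2CCNCC2)CN1)[C@H]1CCCc2cccnc21` gives 14.8 nM in a functional assay on CCRF-CEM cells for antagonist activity at C-X-C chemokine receptor type 4 (Homo sapiens), read by calcium flux, with stated times of 25 min and 90 s; on this read-out lower numbers stand for stronger inhibition and higher numbers for weaker inhibition
compound 2 `CC(C)N(C[C@H]1Cc2c(cccc2N2CCNCC2)CN1)[C@H]1CCCc2cccnc21` gives 364 nM in this assay
compound 3 `Cc1cnc2c(c1)CCC[C@@H]2N(C)C[C@H]1Cc2c(cccc2N2CCNCC2)CN1` gives 16.1 nM in this assay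

Compound 3 stands second highest of the three numbers in this assay; its nearest neighbour is compound 1, within the scatter, and its furthest is compound 2, well beyond it. Among the compounds with values here, the one step among the measured compounds, a 25-fold higher number from compound 1 to compound 2 (1.39 log units; beyond the scatter), concerns the group on the amine nitrogen and is large; nothing measured touches the aromatic ring.

Compound 4 `CN(C[C@H]1Cc2c(cccc2N2CCNCC2)CN1)[C@H]1CCCc2cccnc21` differs from compound 3 only by hydrogen in place of methyl on an aromatic carbon. Within the data shown here, no measured step bears on this change, so the expectation rests on compound 3 alone and is for no step beyond the scatter, a 1.0-fold lower number from compound 3 to compound 4 (0.00 log units; within the scatter). Compound 4 is therefore estimated at 16 nM in this assay, with a range of 6 nM to 45 nM.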

Compound 4, half-maximal inhibitory concentration: 6.08 nM
Estimate against measurement, compound 4: 2.6-fold (0.42 log units) above; measured number inside the range.
By their numbers in this assay, from the lowest: compound 4; then compounds 1 and 3 (each within the scatter of the next); then compound 2.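

Hydrogen in place of methyl on this aromatic carbon, two atoms from the ring nitrogen, is not a silent change: it gives a 2.6-fold lower number from compound 3 to compound 4 (0.42 log units; beyond the scatter), so this position registers in the read-out. With the aromatic carbon unsubstituted, the group on the amine nitrogen now forms an order across three compounds, with methyl lowest, through a 2.4-fold lower number from compound 1 to compound 4 (0.39 log units; beyond the scatter) from ethyl and a 60-fold lower number from compound 2 to compound 4 (1.78 log units; beyond the scatter) from isopropyl, and none of the three goes against it. Nothing available accounts for either the aromatic or the amine nitrogen step.

On these data alone, it remains open how fluorine or a methoxy group on the same aromatic carbon would read, and whether hydrogen or cyclopropyl on the amine nitrogen would fit the order. Also open, as far as these compounds go, is whether the aromatic methyl step would hold with ethyl on that nitrogen.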